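The source may report more compounds than this note shows. Statements on the series, on what has been measured and on what is new or still open speak of the compounds shown alone.

Measured compounds in an assay on microsomes from liver for inhibition of acyl-CoA desaturase 1 (Rattus norvegicus); a lower number here means a stronger inhibitor, a higher number a weaker inhibitor:
compound 2 `c1cc2c(c(OC3CCN(c4ccc(-n5ccnc5)nn4)CC3)c1)CCC2`, 10 nM
compound 1 `O=C(NCCC1CC1)c1ccc(N2CCC(Oc3ccccc3C(F)(F)F)CC2)nn1`, 14 nM
compound 3 `CC(C)(C)c1nnc(-c2ccc(N3CCC(Oc4ccccc4C(F)(F)F)CC3)nn2)s1`, 710 nM

Compound 2 gives the lowest of the three numbers in this assay; compound 1 lies within the scatter of it, compound 3 far beyond. Compound 4 `c1cn(-c2ccc(N3CCC(Oc4ccc5c(c4)CCC5)CC3)nn2)cn1` differs from compound 2 by 2,3-dihydro-1H-inden-5-yl in place of 2,3-dihydro-1H-inden-4-yl on an oxygen on a saturated carbon. Among the compounds with values here, the only measured step, a 51-fold higher number from compound 1 to compound 3 (1.71 log units; beyond the scatter), concerns a replacement on an aromatic carbon of the shared core, not the aryl ether, so it does not bear on this change. Within the data shown here, no measured pair shows what moving the ether attachment around the indane does; the expectation therefore rests on compound 2 at 10 nM alone. A small step of a 2.0-fold higher number from compound 2 to compound 4 (0.30 log units; within the scatter) is expected, direction uncertain, likely within the scatter. Compound 4 is estimated at 20 nM, range 5 nM to 100 nM.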

Compound 4, half-maximal inhibitory concentration: 62 nM
Compound 4: the middle estimate sits 3.1-fold (0.49 log units) below what was measured; the measured number falls inside the stated range.
By their numbers in this assay, from the lowest: compounds 2 and 1 (each within the scatter of the next); then compound 4; then compound 3.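

In this assay, the aryl ether position is sensitive to the point of attachment alone: with the same atoms joined differently, 2,3-dihydro-1H-inden-5-yl in place of 2,3-dihydro-1H-inden-4-yl gives a 6.2-fold higher number from compound 2 to compound 4 (0.79 log units; beyond the scatter). The earlier compounds shown here held no such isomer pair, and this step is beyond the scatter. No supporting data explain the shift. Still open, from the compounds shown here alone, is whether the same change would give a similar step with the other substituents on the shared core, such as (2-cyclopropylethyl)carbamoyl. Also open, going by these compounds, is how an amine or a carboxylic acid on the 2,3-dihydro-1H-inden-4-yl group would read.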